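Swapping an Aminomethyl Side Chain for Pyridine

The source may hold more compounds than are shown below. What is called first, only, known or untested is meant among the compounds shown, and "the series" means these compounds.

Three compounds sharing a dihydropyrazole core carrying a phenyl group have been run in a physicochemical assay for lipophilicity, read by HPLC, measured as chromatographic lipophilicity, at pH 7.4; on this read-out higher numbers stand for higher lipophilicity and lower numbers for lower lipophilicity. Compound 1, `C[C@@H]1C=NN(C(=O)C(C)(C)C)[C@@H]1c1ccccc1`, gives 6.5. Compound 3, `O=C(c1cscn1)N1CCC(C(=O)N2N=CC[C@H]2c2ccccc2)CC1`, gives 3. Compound 2, `CC(C)(CN)C(=O)N1N=CCC1c1ccccc1`, gives 1.4, the lowest of the three numbers, standing well beyond the scatter below both compound 3 and compound 1.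

The next compound, compound 4, `O=C(c1ccccn1)N1N=CCC1c1ccccc1`, keeps the shared core and the amide carbonyl of compound 2 but changes what sits on that carbonyl carbon: pyridin-2-yl in place of 1-(aminomethyl)-1-methylethyl on a carbonyl carbon. With this change, the one hydrogen-bond donor of the departing group is gone, while an aromatic ring comes in. The three measured compounds show that the group on this carbonyl can shift the read-out over a wide span, from the value of compound 2 up to that of compound 1.

No directly measured pair tells how large this particular swap is, so the expectation rests on the spread shown. A clear rise in this assay is expected, because compound 2 sits at 1.4, far under its neighbours. The expected step is a number 2.40 log units higher from compound 2 to compound 4 (beyond the scatter). Compound 4 is therefore estimated at 3.8, within a range from 3 to 4.6.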

Compound 4, distribution coefficient: 2.4
Estimate against measurement, compound 4: 1.40 log units above; measured number outside the range, below it.
By their numbers in this assay, from the lowest: compound 2; then compound 4; then compound 3; then compound 1.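

On a carbonyl carbon whose other neighbour is an amide-type nitrogen in a ring, pyridin-2-yl in place of 1-(aminomethyl)-1-methylethyl now gives a direct reading of one change at this position: this assay shows a number 1.00 log units higher from compound 2 to compound 4 (beyond the scatter). The earlier compounds shown here offered no pair differing in only one place, so the wide spread of their numbers could not be tied to any single swap, whereas this pair puts a size on one: a modest step, though larger than the usual scatter of repeated measurements. No measurement among those shown explains why the step has this size.

This single swap removes the aminomethyl-bearing chain and brings in an aromatic ring at the same time, so these compounds cannot separate what each part contributes to the step. From the compounds shown here alone, it remains open how the number would move with a cyclohexyl ring on the same carbonyl carbon, which would keep a ring without the aromatic nitrogen, or with a longer chain ending in an amine, which would keep the amine further out.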